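This account rests on a few compounds, and the source may have more. Where it says the series, first, only, none or still open, it means among the compounds named here.

Compound 1 `COc1cc(NS(=O)(=O)c2ccc(N3CCNC3=O)cc2)cc(OC)c1OC`: 45 nM
Compound 2 `O=C1NCCN1c1ccc(S(=O)(=O)Nc2cccc(Cl)c2)cc1`: 200 nM

In a functional assay on MDA-MB-231 cells (Homo sapiens) for antiproliferative activity, read by sulforhodamine B assay, with a stated time of 48 h (a lower number here means a stronger inhibitor, a higher number a weaker inhibitor), compound 1 gives 45 nM and stands lowest of the two numbers, while compound 2 gives 200 nM and stands higher, beyond the usual scatter. Compound 3 (`COc1cc(NS(=O)(=O)c2ccc(N3CCNC3=O)cc2)cc(OC)c1`) has not yet been measured. It differs from compound 1 by hydrogen in place of methoxy on an aromatic carbon, ortho to two methoxy groups and para to a large group.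

Going by the values given here, no measured pair isolates this change, so the data give no direct size for it. Among the compounds with values here, with compound 1 at 45 nM as the lowest number so far and compound 2 at 200 nM as the only other point, a rise seems likelier than a fall in this assay for this change. The estimated step is a 4.0-fold higher number from compound 1 to compound 3 (0.60 log units; beyond the scatter) and it is expected to run toward a weaker inhibitor, beyond the scatter, although a step within the scatter cannot be ruled out. For compound 3 the expected value is 180 nM, with an estimated range from 50 nM to 800 nM.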

Compound 3, half-maximal inhibitory concentration: 340 nM
Beside the measured number, compound 3's estimate is 1.9-fold (0.28 log units) below it, and the stated range covers the measured number.
By their numbers in this assay, from the lowest: compound 1; then compounds 2 and 3 (each within the scatter of the next).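

In this assay, the methoxy ortho to two methoxy groups and para to a large group now has a measured size: replacing it with hydrogen gives a 7.6-fold higher number from compound 1 to compound 3 (0.88 log units; beyond the scatter), a step toward a weaker inhibitor. Compound 3 keeps the other two methoxy groups, so those two alone do not preserve the number of compound 1 on this core, and the loss of this single methoxy is enough to produce a change beyond the scatter. Nothing given here accounts for the size of this step, and the data offer no independent measurement that would explain it.

The compounds shown leave open whether the step depends on methoxy itself or on having any group at this place, a question that a hydroxyl, a chlorine or an ethoxy on the same carbon would address. They also leave open how much each of the other two methoxy groups contributes, and whether this step would have the same size with other groups elsewhere on that ring.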